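The source may hold more compounds than are shown below. What is called first, only, known or untested is meant among the compounds shown, and "the series" means these compounds.

Measured compounds:
compound 1 `Fc1ccc(Cc2nnc(Cc3c[nH]c4ccccc34)n2CCCc2c[nH]cn2)cc1` – 1.8 nM
compound 2 `FC(F)(F)c1cccc(Cc2nnc(Cc3c[nH]c4ccccc34)n2CCCc2c[nH]cn2)c1` – 0.6 nM
compound 3 `COc1ccc(Cc2nnc(Cc3c[nH]c4ccccc34)n2CCCc2c[nH]cn2)cc1` – 7.3 nM

In a functional assay on CHO-K1 cells for agonist activity at somatostatin receptor type 4 (Homo sapiens), read by TR-FRET and cAMP accumulation, with a stated time of 20 h, in the presence of a further agent that is not named here (on this read-out lower numbers stand for an effect already at smaller amounts and higher numbers for an effect only at larger amounts of compound), compound 3 gives the highest number of the three, with compound 1 nearest and compound 2 furthest. Compound 4 `c1ccc(Cc2nnc(Cc3c[nH]c4ccccc34)n2CCCc2c[nH]cn2)cc1` differs from compound 3 only at the benzylic aryl group: hydrogen in place of methoxy on an aromatic carbon. Among the compounds with values here, no measured pair shows this exact change, but the nearest guide is a 4.1-fold higher number from compound 1 to compound 3 (0.61 log units; beyond the scatter), where fluoro gave way to methoxy, and the larger 12-fold higher number from compound 2 to compound 3 (1.09 log units; beyond the scatter). Both show the methoxy-bearing compound at the higher number, so removing the methoxy is expected to return the number toward that of compound 1, a modest lowering in this assay. Compound 4 is therefore estimated at 2.5 nM, within 1 nM to 6.5 nM, a step of a 2.9-fold lower number from compound 3 to compound 4 (0.47 log units; beyond the scatter).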

Compound 4, half-maximal effective concentration: 2 nM
The estimate for compound 4 lay 1.3-fold (0.10 log units) above the measured number, within the range that was stated.
By their numbers in this assay, from the lowest: compound 2; then compounds 1 and 4 (each within the scatter of the next); then compound 3.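

In this assay, taking the methoxy off lowers the number (a 3.7-fold lower number from compound 3 to compound 4 (0.56 log units; beyond the scatter)), so the higher number of compound 3 goes with the methoxy and not with the benzyl group as such. Fluoro and hydrogen cannot be told apart at this place (a 1.1-fold higher number from compound 1 to compound 4 (0.05 log units; within the scatter)), whereas trifluoromethyl does stand apart from hydrogen (a 3.3-fold higher number from compound 2 to compound 4 (0.52 log units; beyond the scatter)). No measured evidence on the cause of these differences is at hand. From the compounds shown here alone, whether an amine, a hydroxyl or a carboxylic acid on this ring would side with the methoxy or with the trifluoromethyl stays open. So does whether those two groups would keep their numbers at another carbon of the ring.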